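The compounds below may be only part of what the source reports. "The series", "measured", "known", "first", "only" and "open" are said of these compounds alone.

The shared core of compound 1 `C[C@H]1[C@H](NCc2cncnc2)C[C@H]2C[C@@H]1C2(C)C` carries a pyrimidin-5-yl group on a saturated chain carbon bound to an amine nitrogen. In an ADME assay on MDCK cells (Canis lupus familiaris) for cytotoxicity, read by microscopy, with a stated time of 48 h (on this read-out higher numbers stand for lower toxicity in this test and lower numbers for higher toxicity in this test), compound 1 gives > 100000 nM, which is a limit of the assay and not a number. Within the data gathered so far compound 1 therefore stands at the limit of > 100000 nM in this assay, at which 1 of the 2 values shown sits. Going by the values given here, compound 2 `C[C@H]1[C@H](NCc2cc(-c3ccccc3)cs2)C[C@H]2C[C@@H]1C2(C)C` gives 5000 nM in this assay, a number rather than a limit; no step between compound 1 and compound 2 has been worked out, so only the two values themselves speak. Compound 3 `C[C@H]1[C@H](NCc2ccco2)C[C@H]2C[C@@H]1C2(C)C` has not yet been measured in this assay. It differs from compound 1 by furan-2-yl in place of pyrimidin-5-yl on a saturated chain carbon bound to an amine nitrogen. Since compound 1 is known only as a limit, the step expected in this assay is an at least 2.0-fold lower number from compound 1 to compound 3 (0.30 log units; that floor lies within the scatter), a shift toward higher toxicity that may reach beyond the usual scatter. For compound 3 an estimated value of 50000 nM is expected, within a range from 12000 nM to 100000 nM.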

Compound 3, minimum cytotoxic concentration: 50000 nM
Compound 3: middle estimate and measured number agree at the digits printed; low and high end bracket the measured number.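

Furan-2-yl in place of pyrimidin-5-yl on a saturated chain carbon bound to an amine nitrogen gives an at least 2.0-fold lower number from compound 1 to compound 3 (0.30 log units; that floor lies within the scatter) in this assay. This change therefore brings a measured number at this place, with a five-membered aromatic ring with 1 hetero atom where a six-membered aromatic ring with 2 hetero atoms stood, although only a floor within the scatter is established for the step. Compound 1 is known only as a limit, and the step cannot be sized further for that reason: the limit of > 100000 nM in this assay, at which 1 of the 3 values shown sits.

Going by these compounds, how far the true step reaches, and whether it passes beyond the scatter, stays open. Also open, on these data alone, is how this assay would read with a carboxylic acid or an amine at this place on the shared core.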